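Swapping a hexyl ester for a benzyl ester

A few compounds are considered here, and "the series" means these few. Any claim that something is new, unique, unknown or untested is made for them only; others in the source may bear on it.

Four compounds share one core and differ only in the group attached to a carbonyl carbon. Compound 1 `CCOc1cc(NC(=O)C2(NC(=O)c3ccc4c(C5CCCC5)c(-c5ncc(Cl)cn5)n(C)c4c3)CCC2)ccc1/C=C/C(=O)N[C@@H](CC(=O)O)C(N)=O` carries a (1-carbamoyl-2-carboxyethyl)amino group there; in an ADME assay on stomach for pharmacokinetics, in simulated gastric fluid (a higher number here means that the compound lasts longer, a lower number that the compound disappears faster), compound 1 gives > 5 h, which is a limit of the measurement rather than a number. Compound 2 `CCCOC(=O)/C=C/c1ccc(NC(=O)C2(NC(=O)c3ccc4c(C5CCCC5)c(-c5ncc(Cl)cn5)n(C)c4c3)CCC2)cc1OCC` carries propoxy instead, and in this assay compound 2 gives 2.23 h. Compound 3 `CCCCCCOC(=O)/C=C/c1ccc(NC(=O)C2(NC(=O)c3ccc4c(C5CCCC5)c(-c5ncc(Cl)cn5)n(C)c4c3)CCC2)cc1OCC` carries hexyloxy, and in this assay compound 3 gives 0.883 h. Of the two actual numbers, compound 3 stands lowest. The steps between the measured compounds all run downward: an at least 2.2-fold lower number from compound 1 to compound 2 (0.35 log units; beyond the scatter), an at least 5.6-fold lower number from compound 1 to compound 3 (0.75 log units; beyond the scatter), and a 2.5-fold lower number from compound 2 to compound 3 (0.40 log units; beyond the scatter). The first two start from a limit (the limit of > 5 h in this assay, at which 1 of the 3 values shown sits), so their true size is open.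

Compound 4 `CCOc1cc(NC(=O)C2(NC(=O)c3ccc4c(C5CCCC5)c(-c5ncc(Cl)cn5)n(C)c4c3)CCC2)ccc1/C=C/C(=O)OCc1ccccc1` differs from compound 3 as follows: phenyl in place of pentyl on a saturated chain carbon bound to an oxygen next to a carbonyl group. Going by the values given here, only one measured step exchanges one ester chain for another, and it is of modest size: a 2.5-fold lower number from compound 2 to compound 3 (0.40 log units; beyond the scatter). The new change replaces an open chain with a ring of similar bulk rather than lengthening it, so the expected step is small, within the usual scatter: a 1.4-fold higher number from compound 3 to compound 4 (0.13 log units; within the scatter). Compound 4 is therefore estimated at 1.2 h, with a likely range from 0.5 h to 3 h.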

Compound 4, half-life: 1.83 h
For compound 4 the middle estimate is 1.5-fold (0.18 log units) below the measured one, and the stated range covers the measured number.
By their numbers in this assay, from the lowest: compound 3; then compounds 4 and 2 (each within the scatter of the next). At a limit, above all of these: compound 1.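

In this assay a ring and an open chain do not read alike at this place: going from hexyl to benzyl gives a 2.1-fold higher number from compound 3 to compound 4 (0.32 log units; beyond the scatter), a modest but real step. Against the propyl ester, the benzyl ester shows a 1.2-fold lower number from compound 2 to compound 4 (0.09 log units; within the scatter) and so no real difference, which means compound 4 goes against the fall in the number seen when the chain grew from propyl to hexyl. Going by these compounds, the benzyl ester also joins the other two esters in standing apart from the amide of compound 1, with an at least 2.7-fold lower number from compound 1 to compound 4 (0.43 log units; beyond the scatter) as a step whose true size stays open, since it starts from a limit: the limit of > 5 h in this assay, at which 1 of the 4 values shown sits.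

The compounds shown leave open how a methoxy group or a chlorine on the phenyl ring, or a phenylethyl group with one more carbon in its chain, would move the number in this assay. They also leave open what a free carboxylic acid or a simple amide at this carbonyl carbon would give, and so whether the high end seen with compound 1 needs its whole (1-carbamoyl-2-carboxyethyl)amino group.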